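This account rests on a few compounds, and the source may have more. Where it says the series, first, only, none or still open, it means among the compounds named here.

Working notes on the hydroxamate chain series.

Two cores carry a hydroxamic acid on an alkyl chain attached to an aromatic nitrogen. Compound 1 `Nc1ncnc2c1c(-c1cnc3[nH]ccc3c1)nn2CCCCCCCCCC(=O)NO` and compound 2 `Nc1ncnc2c1c(-c1cnc3[nH]ccc3c1)nn2CCCCCCC(=O)NO` share one core and differ only in chain length; compound 3 `Nc1nc2cc(-c3nn(CCCCCC(=O)NO)c4ncnc(N)c34)ccc2o1` has the other core, and the difference between the two cores is not broken down here. All three have been run in a functional assay on Hep 3B2 cells (Homo sapiens) for inhibition, read by MTT assay, with a stated time of 72 h; a higher number here means a weaker inhibitor, a lower number a stronger inhibitor. In this assay compound 1 gives 17200 nM, compound 2 gives 26300 nM and compound 3 gives 34200 nM. Among the compounds with values here, the only counted step among them is the chain extension (3-(hydroxycarbamoyl)propyl in place of hydroxycarbamoyl on a saturated chain carbon, six bonds along the chain from an aromatic nitrogen), which gives a 1.5-fold lower number from compound 2 to compound 1 (0.18 log units; within the scatter); no word of order between compound 1 and compound 2 is warranted on that basis.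

Compound 4 `Nc1nc2cc(-c3nn(CCCCCCCCC(=O)NO)c4ncnc(N)c34)ccc2o1` has not been measured. It is made from compound 3 by 3-(hydroxycarbamoyl)propyl in place of hydroxycarbamoyl on a saturated chain carbon, five bonds along the chain from an aromatic nitrogen. This is the same kind of change as that from compound 2 to compound 1, but not the same: in one it sits six bonds along the chain from an aromatic nitrogen, in the other five bonds along the chain from an aromatic nitrogen, and the core is different. Within the data shown here, with only a single precedent, the expectation is of a step of about the same size, so compound 4 is expected to show a 1.4-fold lower number from compound 3 to compound 4 (0.14 log units; within the scatter), resting on the step of a 1.5-fold lower number from compound 2 to compound 1 (0.18 log units; within the scatter) seen in the other core. Compound 4 is therefore estimated at 25000 nM in this assay, with a range from 12000 nM to 55000 nM.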

Compound 4, half-maximal inhibitory concentration: 8890 nM
Beside the measured number, compound 4's estimate is 2.8-fold (0.45 log units) above it; measured number outside the range, below it.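

Working from this assay, extending hydroxycarbamoyl to 3-(hydroxycarbamoyl)propyl on the core of compound 3 gives a 3.8-fold lower number from compound 3 to compound 4 (0.59 log units; beyond the scatter), so on this core the change has a readable effect, and it is modest. Set beside the earlier step on the other core, the change cannot be said to behave differently on the two cores: the same change on two cores in this assay, a 1.5-fold lower number (0.18 log units; within the scatter) from compound 2 to compound 1 and a 3.8-fold lower number (0.59 log units; beyond the scatter) from compound 3 to compound 4, 2.5-fold (0.40 log units) apart, within the scatter of two such steps. Within the data shown here, this shows that the two results are compatible with a single step carried across both cores, but it does not show that the step has a fixed size, since the evidence is only two pairs in one assay, the step on the other core is itself within the scatter, the chains being extended differ in length, and a gain on the core of compound 3 says nothing about the reason for it.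

On these data alone, it remains open whether a still longer chain on either core would continue this trend or reverse it, and whether intermediate chain lengths would fall on the same line. As far as these compounds go, it is also open whether a carboxylic acid or a primary amide in place of the hydroxycarbamoyl group at the chain end would keep any of this activity.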